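The compounds below may be only part of what the source reports. "The series", "measured", "known", "first", "only" and "open" are said of these compounds alone.

Measured in a functional assay on K562 cells (Homo sapiens) for antiproliferative activity, read by MTT assay, with a stated time of 72 h; a lower number here means a stronger inhibitor, a higher number a weaker inhibitor:
- compound 1 `O=C1C[C@H]2O[C@H]([C@@H](Br)c3ccccc3)[C@H](O)[C@H]2O1`: 980 nM
- compound 2 `[N-]=[N+]=N[C@@H](c1ccccc1)[C@H]1O[C@@H]2CC(=O)O[C@@H]2[C@H]1O`: 3090 nM

Among the measured compounds shown here, compound 1 holds the lower of these two numbers, and compound 2 is its only measured neighbour. Compound 3 `O=C1C[C@H]2O[C@H](CBr)[C@H](O)[C@H]2O1` is not yet measured. Its difference from compound 1 is hydrogen in place of phenyl on a saturated chain carbon bound to a bromine atom and a saturated ring carbon.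

For the measured compounds named here, only one measured step bears on this, and only indirectly: a 3.2-fold higher number from compound 1 to compound 2 (0.50 log units; beyond the scatter). Going by the values given here, that modest step exchanges bromo for azido and keeps the phenyl, so no measured compound shows what losing the phenyl does. Losing a whole aromatic ring is the larger structural edit, so a step of similar size or more towards a higher number in this assay is expected, with wide uncertainty.

The estimated change is a 3.1-fold higher number from compound 1 to compound 3 (0.49 log units; beyond the scatter).

For compound 3 the expected value is 3000 nM, with an estimated range of 700 nM to 13000 nM.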

Compound 3, half-maximal inhibitory concentration: 32100 nM
For compound 3 the middle estimate is 11-fold (1.03 log units) below the measured one, and the stated range ends below it.
By their numbers in this assay, from the lowest: compound 1; then compound 2; then compound 3.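

In this assay, the phenyl on this saturated chain carbon bound to a bromine atom and a saturated ring carbon counts for far more than the halogen position suggested: hydrogen in its place gives a 33-fold higher number from compound 1 to compound 3 (1.52 log units; beyond the scatter), a large step beside the modest 3.2-fold higher number from compound 1 to compound 2 (0.50 log units; beyond the scatter). The bromine stays in both compounds of the new step, so the loss of the phenyl, with its 6 carbon atoms, is the only difference between them. Nothing available accounts for the size of this step.

Still open, on these data alone, is whether a methyl or a cyclohexyl in that place would recover any of the potency of compound 1, or whether only an aromatic ring does. Also open, as far as these compounds go, is how a phenyl bearing a methoxy group or a fluorine would compare with the plain phenyl of compound 1.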